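From 4-chlorophenyl to 2-chlorophenyl on an aromatic nitrogen

The source may hold more compounds than are shown below. What is called first, only, known or untested is meant among the compounds shown, and "the series" means these compounds.

Within the data shown here, in a functional assay on HepG2 cells (Homo sapiens) for inhibition, read by MTT assay, with a stated time of 72 h (a lower number here means a stronger inhibitor, a higher number a weaker inhibitor), compound 2 (`Cc1cc2occ(-c3nc(-c4ccccc4)c(-c4ccccc4)n3-c3ccc(Cl)cc3)c(=O)c2cc1Cl`) gives 1560 nM and holds the lower of the two numbers so far, while compound 1 (`COc1ccccc1-n1c(-c2coc3cc(C)c(Cl)cc3c2=O)nc(-c2ccccc2)c1-c1ccccc1`) gives 12500 nM on the same measure. Among the measured compounds shown here, the one measured step is an 8.0-fold lower number from compound 1 to compound 2 (0.90 log units; beyond the scatter) and it comes with 4-chlorophenyl in place of 2-methoxyphenyl on an aromatic nitrogen.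

Compound 3 (`Cc1cc2occ(-c3nc(-c4ccccc4)c(-c4ccccc4)n3-c3ccccc3Cl)c(=O)c2cc1Cl`) keeps the shared core and has the same atoms as compound 2 but carries 2-chlorophenyl in place of 4-chlorophenyl on that nitrogen (2-chlorophenyl in place of 4-chlorophenyl on an aromatic nitrogen). For the measured compounds named here, the new group shares its chlorine with compound 2 and its numbering with the 2-methoxyphenyl of compound 1, so the single step bears only in part. Going by the values given here, no measured pair separates the identity of the group from its placement. Among the compounds with values here, with an 8.0-fold lower number from compound 1 to compound 2 (0.90 log units; beyond the scatter) as the only guide, part of that size is expected to return, in the upward direction. The expected change is a 2.6-fold higher number from compound 2 to compound 3 (0.41 log units; beyond the scatter) in this assay as an estimate. For compound 3 the estimate is 4000 nM with an expected range of 1300 nM to 13000 nM in this assay on present evidence.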

Compound 3, half-maximal inhibitory concentration: 6250 nM
For compound 3 the middle estimate is 1.6-fold (0.19 log units) below the measured one, and the stated range covers the measured number.
By their numbers in this assay, from the lowest: compound 2; then compounds 3 and 1 (each within the scatter of the next).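

In this assay, moving the chlorine with the atoms otherwise unchanged, 2-chlorophenyl in place of 4-chlorophenyl on the aromatic nitrogen, gives a 4.0-fold higher number from compound 2 to compound 3 (0.60 log units; beyond the scatter), so placement alone changes the read-out at this position. Between the two groups numbered 2, chloro in place of methoxy on an aromatic carbon gives a 2.0-fold lower number from compound 1 to compound 3 (0.30 log units; within the scatter), which means that the earlier step, an 8.0-fold lower number from compound 1 to compound 2 (0.90 log units; beyond the scatter), can now be read as a placement step beyond the scatter and an identity step within it. No measured information on these compounds accounts for the effect of placement.

As far as these compounds go, whether a nitrile or an amine in place of the chlorine of 4-chlorophenyl would retain the lower number of compound 2 stays open, so the result cannot yet be assigned to that group in general rather than to chloro in particular. From the compounds shown here alone, the phenyl groups and the rest of the shared core are the same in compound 1, compound 2 and compound 3, so what they contribute also stays open.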